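Anilinodiene series: cytotoxicity on Raji cells, one aryl change

The source may report more compounds than this note shows. Statements on the series, on what has been measured and on what is new or still open speak of the compounds shown alone.

Measured so far:
Compound 1, `C=C[C@@](C)(/C=C/c1ccc(O)cc1)CC/C=C(\C)C(=O)OCC`, gives > 26000 nM in a functional assay on Raji cells (Homo sapiens) for cytotoxicity, with a stated time of 72 h (on this read-out higher numbers stand for an effect only at larger amounts of compound and lower numbers for an effect already at smaller amounts), a limit of the assay.
Compound 2, `C=C[C@@](C)(/C=C/c1ccc(Nc2ccc(OC)c(OC)c2)cc1)CCC=C(C)C`, gives > 26000 nM in this assay, also a limit.
Compound 3, `C=C[C@@](C)(/C=C/c1ccc(Nc2ccc(OC)c(F)c2)cc1)CCC=C(C)C`, gives > 26000 nM in this assay, again a limit.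

Compound 3 therefore stands at the same limit as every other member shown, and the limit of > 26000 nM in this assay, at which 3 of the 3 values shown sit, records that all three values sit there. Among the measured compounds shown here, the one measured step, a step that the two limits leave unreadable from compound 2 to compound 3, is unreadable for this reason.

Compound 4, `C=C[C@@](C)(/C=C/c1ccc(Nc2ccc(Cl)cc2)cc1)CCC=C(C)C`, has not been measured. It differs from compound 3 in this way: 4-chlorophenyl in place of 3-fluoro-4-methoxyphenyl on a nitrogen on an aromatic ring. No readable step bears on this change, so no size of step is expected beyond the scatter, and compound 4 is expected to stand at or near the same limit as compound 3, with a step that the limit leaves unreadable from compound 3 to compound 4 estimated as essentially no change. For compound 4 the estimate in this assay is 30000 nM, with a range from 8000 nM to 120000 nM.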

Compound 4, half-maximal effective concentration: > 26000 nM
Compound 4: only a limit was reported (the forecaster's own chance of this, stated with the estimate: 80%); the middle value is on the limit's open side.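

The step between compound 3 and compound 4 cannot be read, because both values are limits: the limit of > 26000 nM in this assay, at which 4 of the 4 values shown sit.

The compounds shown leave open whether any aryl group on the nitrogen gives a measurable effect in this assay, and how large one change would be.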